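Indole replacement on the arylidene carbon of compound 1

The compounds below may be only part of what the source reports. "The series", "measured", "known", "first", "only" and "open" are said of these compounds alone.

Compound 1 `Cc1ccc(CS/C(=C/c2ccccc2F)C(=O)c2ccc(Cl)cc2)cc1` sits at the weak end of the three compounds measured in a functional assay on DU-145 cells (Homo sapiens) for inhibition, read by trypan blue exclusion, with a stated time of 96 h; on this read-out higher numbers stand for weaker inhibition of growth and lower numbers for stronger inhibition of growth: compound 1 gives 10000 nM, the highest of the three numbers. Compound 2 `COc1ccccc1/C=C(\C(=O)c1ccc(Br)cc1)S(=O)(=O)c1ccc(C)cc1` gives 1000 nM in this assay, and compound 3 `Cc1ccc(CS/C(=C/c2ccccc2OCc2ccccc2)C(=O)c2ccc(Cl)cc2)cc1` gives 1000 nM, so compound 1 is a step beyond the scatter from both.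

Compound 4 `Cc1ccc(CS/C(=C/c2c[nH]c3ccc(Br)cc23)C(=O)c2ccc(Cl)cc2)cc1` keeps the shared core of compound 1 and differs only at one site: 5-bromo-1H-indol-3-yl in place of 2-fluorophenyl on a double-bonded chain carbon bound to a double-bonded chain carbon.

Within the data shown here, only one measured step bears on this change. It replaces the substituent of the same aromatic ring, and it is a 10-fold lower number from compound 1 to compound 3 (1.00 log units; beyond the scatter). Among the measured compounds shown here, no measured step swaps the ring itself for a fused two-ring system carrying a hydrogen-bond donor, so the size of the present change is not covered by the data; the one relevant step says that altering this part of the core moves the number well beyond the scatter and in the direction of stronger growth inhibition.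

Compound 4 is therefore expected to follow that direction, with an estimated step of a 6.7-fold lower number from compound 1 to compound 4 (0.82 log units; beyond the scatter) in this assay. The estimate for compound 4 is 1500 nM, with an expected range from 300 nM to 10000 nM.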

Compound 4, concentration for 50% growth inhibition: 1000 nM
Estimate against measurement, compound 4: 1.5-fold (0.18 log units) above; measured number inside the range.
By their numbers in this assay, from the lowest: compounds 2, 3 and 4 (each within the scatter of the next); then compound 1.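

Working notes on the arylidene position: in this assay, the change is not limited to a substituent on the retained ring, as the whole 2-fluorophenyl group can be exchanged, and 5-bromo-1H-indol-3-yl in its place gives a 10-fold lower number from compound 1 to compound 4 (1.00 log units; beyond the scatter). Two quite different changes at this place now end at the same printed number, with compound 3 at 1000 nM and compound 4 at 1000 nM, so the stronger growth inhibition seen with benzyloxy is not tied to that group alone. Nothing available accounts for either step, and no measurement explains why the two numbers coincide.

Still open, from the compounds shown here alone, is how the step from the 2-fluorophenyl group divides among the bromine, the indole nitrogen with its hydrogen and the larger ring system, as all three enter together in compound 4. A plain 1H-indol-3-yl group and a 5-bromo-1-methyl-1H-indol-3-yl group would pull these parts apart, and a carboxylic acid or an amine on the indole would test whether the number can move lower at this position.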